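Cyclobutyl for oxetan-3-yl: working notes

This account rests on a few compounds, and the source may have more. Where it says the series, first, only, none or still open, it means among the compounds named here.

Measured in a functional assay on MCF7 cells (Homo sapiens) for antiproliferative activity, read by MTT assay, with a stated time of 48 h; on this read-out higher numbers stand for weaker inhibition and lower numbers for stronger inhibition:
- compound 1 `COc1cc(-c2nnc3c(OC4CCC4)cc(-c4ccc5[nH]ccc5c4)cn23)cc(OC)c1OC`: 267 nM
- compound 2 `COc1cc(-c2nnc3c(OC4COC4)cc(-c4ccc5c(ccn5C)c4)cn23)cc(OC)c1OC`: 1900 nM

Compound 2, at 1900 nM, holds the higher of the two numbers, and its gap to compound 1 lies beyond the scatter. Compound 3 `COc1cc(-c2nnc3c(OC4CCC4)cc(-c4ccc5c(ccn5C)c4)cn23)cc(OC)c1OC` has not yet been measured. Its difference from compound 2 is cyclobutyl in place of oxetan-3-yl on an oxygen on an aromatic ring. Compound 1 also carries cyclobutyl and gives 267 nM, but it differs from compound 2 in a further place, so its gap cannot be assigned to this change alone. Only part of that gap is expected to carry over. The expected result is a 3.2-fold lower number from compound 2 to compound 3 (0.50 log units; beyond the scatter), a lower number in this assay and a step moderately beyond the scatter. For compound 3 the estimate is 600 nM, with an expected range of 180 nM to 2000 nM.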

Compound 3, half-maximal inhibitory concentration: 125 nM
Estimate against measurement, compound 3: 4.8-fold (0.68 log units) above, and the stated range ends above it.
By their numbers in this assay, from the lowest: compound 3; then compound 1; then compound 2.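

In this assay, the change on the oxygen on an aromatic ring can now be read alone: cyclobutyl in place of oxetan-3-yl gives a 15-fold lower number from compound 2 to compound 3 (1.18 log units; beyond the scatter), a large step with the rest of the structure held constant. With cyclobutyl kept, methyl in place of hydrogen on the aromatic nitrogen gives a 2.1-fold lower number from compound 1 to compound 3 (0.33 log units; beyond the scatter), a modest step that is still beyond the scatter. No measurement available here accounts for either step.

As far as these compounds go, it remains open whether the step on this oxygen extends to other groups, such as cyclopentyl, isopropyl or a chain ending in an amine. Also open, from the compounds shown here alone, is whether oxetan-3-yl would give a step of similar size with hydrogen rather than methyl on the aromatic nitrogen.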